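Fluorophenyl for methylcyclohexyl on the carbonyl carbon

The source may hold more compounds than are shown below. What is called first, only, known or untested is meant among the compounds shown, and "the series" means these compounds.

Compound 2 `CC1CCCC(C(=O)N2CC(c3nc(-c4cccc(Cl)c4)no3)C2)C1` is, in an assay on HEK293 cells for negative allosteric modulation of metabotropic glutamate receptor 5 (Homo sapiens), read by FLIPR (on this read-out higher numbers stand for weaker inhibition and lower numbers for stronger inhibition), one of three compounds whose value is only a limit. In this assay compound 2 gives > 10000 nM, a limit and not a number. Compound 1 `O=C(C1CCC(F)(F)CC1)N1CC(c2nc(-c3cccc(F)c3)no2)C1` gives > 10000 nM in this assay, likewise a limit. Compound 3 `O=C(c1ccc(F)c(F)c1)N1CC(c2nc(-c3cccc(F)c3)no2)C1` gives > 10000 nM in this assay, again a limit. Within the data shown here, the only measured step, a step that the two limits leave unreadable from compound 1 to compound 3, is thus hidden between two limits, and all three values sit at the limit of > 10000 nM in this assay, at which 3 of the 3 values shown sit. Compound 4 `O=C(c1ccc(F)cc1)N1CC(c2nc(-c3cccc(Cl)c3)no2)C1` differs from compound 2 in one place: 4-fluorophenyl in place of 3-methylcyclohexyl on a carbonyl carbon. The change from compound 1 to compound 3 is of the same kind, a six-membered aromatic ring of carbon in place of a six-membered non-aromatic ring of carbon on the carbonyl carbon, yet it yields neither size nor direction. With every shown value at the limit, no step beyond the scatter can be expected either way. Compound 4 is therefore estimated at 20000 nM, within 5000 nM to 80000 nM, and most probably reported as a limit once more. The expected step that the limit leaves unreadable from compound 2 to compound 4 is no more than the scatter.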

Compound 4, half-maximal inhibitory concentration: 4000 nM
Compound 4: middle estimate off by 5.0-fold (0.70 log units), on the high side; the whole stated range lies above it.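

Among these compounds, on the carbonyl carbon, 4-fluorophenyl in place of 3-methylcyclohexyl gives, in this assay, an at least 2.5-fold lower number from compound 2 to compound 4 (0.39 log units; beyond the scatter), the only readable step and the first sign that this position can move the read-out. An aromatic ring at this place does not by itself bring a measurable number: compound 3 also carries one and gives > 10000 nM, which is a limit and not a number. The step has a lower bound only, because compound 2 stands at a limit and not at a number: the limit of > 10000 nM in this assay, at which 3 of the 4 values shown sit.

The compounds shown do not separate the part played by the fluorine of the 4-fluorophenyl group from that of the aromatic ring itself. As far as these compounds go, how a phenyl ring without fluorine, a pyridine ring or a ring bearing an amine would read on the carbonyl carbon remains open.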